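This account rests on a few compounds, and the source may have more. Where it says the series, first, only, none or still open, it means among the compounds named here.

Measured so far in a functional assay on U-87MG ATCC cells for antiproliferative activity against U-87 MG (Homo sapiens), read by MTT assay, with a stated time of 48 h (a higher number here means a weaker inhibitor, a lower number a stronger inhibitor), for this series:
- compound 1 `Cc1nc(-c2ccc(Cl)cc2)sc1C(=O)CSc1nc(-c2ccccc2)c(C#N)c(=O)[nH]1` gives 27600 nM
- compound 2 `COc1ccc(-c2nc(C)c(C(=O)CSc3nc(-c4ccc(OC)c(OC)c4)c(C#N)c(=O)[nH]3)s2)cc1` gives 12500 nM

Compound 1 has the higher of the two numbers, and its gap to compound 2 lies beyond the scatter. Among the compounds with values here, only these two values are available, so the series has no measured single-place step.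

Compound 3 `COc1ccc(-c2nc(SCC(=O)c3sc(-c4ccc(Cl)cc4)nc3C)[nH]c(=O)c2C#N)cc1` is still to be measured in this assay and differs from compound 1 in one place, with methoxy in place of hydrogen on an aromatic carbon as the counted difference. This is methoxy in place of hydrogen on an aromatic carbon, or phenyl to 4-methoxyphenyl.

A small step toward a lower number is expected, most likely within the scatter. Within the data shown here, the only guide is compound 2, which also carries methoxy groups and gives 12500 nM as its value, but it differs from compound 1 in more than one place, so the effect of this change alone remains unmeasured. The expected step is a 1.5-fold lower number from compound 1 to compound 3 (0.19 log units; within the scatter) in this series. For compound 3 the estimated value is 18000 nM with an expected range from 8000 nM to 40000 nM in this assay when measured.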

Compound 3, half-maximal inhibitory concentration: 35500 nM
Compound 3: middle estimate off by 2.0-fold (0.29 log units), on the low side, within the range that was stated.
By their numbers in this assay, from the lowest: compound 2; then compounds 1 and 3 (each within the scatter of the next).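

Within the data shown here, the first measured single-place step at this position comes from methoxy in place of hydrogen on an aromatic carbon, para to a large group, and in this assay it reads a 1.3-fold higher number from compound 1 to compound 3 (0.11 log units; within the scatter) and lies within the scatter. Compounds 1 and 3 therefore cannot be told apart in this assay, so phenyl to 4-methoxyphenyl on the core of compound 1 shows no measurable effect on the read-out, and methoxy at this place is compatible with a value in the same range as the hydrogen compound. No measurement on these compounds bears on why the two cannot be separated.

On these data alone, whether another group at the same place, such as an amine, a carboxylic acid or a longer alkoxy chain, would give a step beyond the scatter remains open. Compound 2 gives 12500 nM in this assay but differs from compound 1 in more than one place, so the single-place steps that would account for this value cannot be read from the compounds shown.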